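The compounds below may be only part of what the source reports. "The series", "measured", "known", "first", "only" and "open" are said of these compounds alone.

Measured so far in this series:
Compound 1, `O=C(/C=C/[C@H]1C[C@@H](O)[C@@H](O)C1)Nc1ccc(Cl)cc1` — in an ADME assay on S2 cells (Drosophila melanogaster) for cytotoxicity, read by MTT assay (on this read-out lower numbers stand for an effect already at smaller amounts and higher numbers for an effect only at larger amounts of compound), compound 1 gives > 180000 nM, which is a limit of the assay and not a number.
Compound 2, `O=C(/C=C/[C@H]1C[C@@H](O)[C@@H](O)C1)Nc1ccc(F)cc1` — in this assay compound 2 gives > 180000 nM, again a limit rather than a number.

Both measured values sit at the limit of > 180000 nM in this assay, at which 2 of the 2 values shown sit. Within the data shown here, the one measured step, a step that the two limits leave unreadable from compound 1 to compound 2, cannot be read in size because both of its ends are limits. Compound 2 therefore stands only at a limit in this assay, with no number to place it more precisely.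

Compound 3, `O=C(/C=C/[C@H]1C[C@@H](O)[C@@H](O)C1)Nc1ccc(C(F)(F)F)cc1`, differs from compound 2 in one place: trifluoromethyl in place of fluoro on an aromatic carbon. Among the measured compounds shown here, the only step that bears on a change of the group on that aromatic carbon is the one from compound 1 to compound 2, and it gives neither a size nor a direction. With no readable step to build on, the step of a number no higher from compound 2 to compound 3 (the limit leaves the size open) is expected to be none beyond the scatter, and compound 3 is expected to be reported as a limit again. For compound 3 the estimate in this assay is 180000 nM, in the range 90000 nM to 400000 nM.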

Compound 3, half-maximal effective concentration: > 160000 nM
Compound 3: a limit, no number (the forecaster's own chance of this, stated with the estimate: 85%); the middle value lies beyond the limit too.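

In this assay compound 3 gives > 160000 nM, which is a limit of the assay and not a number. The steps linking compound 3 to compound 1 and to compound 2 therefore cannot be read in size or direction. The compounds shown leave open whether changing the group on that aromatic carbon shifts the value in this assay at all.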